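Pyridin-2-yl in place of 1H-pyrazol-1-yl: solubility outlook

The source may report more compounds than this note shows. Statements on the series, on what has been measured and on what is new or still open speak of the compounds shown alone.

Measured so far in a physicochemical assay for solubility, read by nephelometry, in phosphate buffer, measured as kinetic solubility, at pH 6.5; on this read-out lower numbers stand for lower solubility and higher numbers for higher solubility:
Compound 1, `Cc1cc(C(=O)NNS(=O)(=O)c2ccccc2F)cc(-c2ccccn2)c1`, gives 12.5 ug/mL.
Compound 2, `Cc1cc(C(=O)NNS(=O)(=O)c2ccccc2F)cc(-n2cccn2)c1`, gives 12.5 ug/mL.
Compound 3, `Cc1cc(-n2cccn2)cc(C(=O)NNS(=O)(=O)c2ccccc2)c1F`, gives 6.3 ug/mL.

Compound 1 and compound 2 share one core and differ by pyridin-2-yl in place of 1H-pyrazol-1-yl on an aromatic carbon. Going by the values given here, that step, no change at the digits printed from compound 2 to compound 1 (within the scatter), is the only measured instance of this change. Compound 3 is built from the same atoms as compound 2, joined differently; the difference between the two cores is not broken down here. Compound 3 sits at the lower end of the three numbers, but its gaps to compound 1 and to compound 2 are both within the scatter, so no order among the three can be read from them.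

Compound 4, `Cc1cc(-c2ccccn2)cc(C(=O)NNS(=O)(=O)c2ccccc2)c1F`, has not yet been measured in this assay. It differs from compound 3 by pyridin-2-yl in place of 1H-pyrazol-1-yl on an aromatic carbon. This is the same kind of change as that from compound 2 to compound 1, not the same change: in compound 3 the place is also para to a fluoro group, which the place in compound 2 is not. Because compound 3 gives 6.3 ug/mL and because no change at the digits printed from compound 2 to compound 1 (within the scatter), compound 4 is expected to show no change at the digits printed from compound 3 to compound 4 (within the scatter). The estimate for compound 4 in this assay is therefore 6.3 ug/mL, expected to fall between 3.1 ug/mL and 13 ug/mL.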

Compound 4, solubility: 6.3 ug/mL
The estimate for compound 4 equals the measured number at the digits printed, within the range that was stated.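

In this assay pyridin-2-yl in place of 1H-pyrazol-1-yl gives no change at the digits printed from compound 3 to compound 4 (within the scatter) and on the other core the same kind of change gives no change at the digits printed from compound 2 to compound 1 (within the scatter) so the two measured instances agree, even though the place in compound 3 is para to a fluoro group and the place in compound 2 is not. This shows that the absence of a step beyond the scatter carried from one core to the other in these two pairs, but it does not show that the two groups are interchangeable across the series, and a step within the scatter could still conceal a small real difference in either pair. Nothing in the data shown bears on why the number stays where it does.

The compounds shown leave open how the read-out would respond to a group of a different kind in this place, such as an aliphatic amine, a carboxylic acid or a longer alkyl chain. They also leave open whether pyridin-2-yl in place of 1H-pyrazol-1-yl would again give no step beyond the scatter on a third core, for instance one without the methyl group.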